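Propyl in Place of Benzoyloxy: One Step Seen Once

A few compounds are considered here, and "the series" means these few. Any claim that something is new, unique, unknown or untested is made for them only; others in the source may bear on it.

In an assay on nucleic acid for inhibition of Nucleic Acid, read by fluorescence, tested at 100 uM (on this read-out higher numbers stand for more inhibition at the one concentration tested (going by the name of the read-out) and lower numbers for less inhibition), the measured compounds stand as follows:

compound 1 `CCCCN(CCCC)Cc1cn(CC(O)COC(=O)c2ccccc2)nn1` gives 12%
compound 2 `CCOC(=O)C1CCCN(Cc2cn(CC(O)COC(=O)c3ccccc3)nn2)C1` gives 6%
compound 3 `CCCCC(O)Cn1cc(CN(CCCC)CCCC)nn1` gives 18%

Compound 1 and compound 2 carry different cores; the difference between the two cores is not broken down here. Their two values lie within the usual scatter of each other, so no order between them is claimed. Compound 3 differs from compound 1 by propyl in place of benzoyloxy on a saturated chain carbon, two bonds along the chain from an oxygen on a saturated carbon and this change brought a number 6 percentage points higher from compound 1 to compound 3 (within the scatter). Compound 3 stands beyond the scatter from compound 2.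

Compound 4 `CCCCC(O)Cn1cc(CN2CCCC(C(=O)OCC)C2)nn1` is not yet measured. It differs from compound 2 by propyl in place of benzoyloxy on a saturated chain carbon, two bonds along the chain from an oxygen on a saturated carbon, and the place of the change reads word for word as it does between compound 1 and compound 3, so the two changes are the same change on the two cores. For the measured compounds named here, only this one earlier instance is known, and it lay within the scatter. Going by the values given here, compound 4 is therefore expected to move by a number 6 percentage points higher from compound 2 to compound 4 (within the scatter) from compound 2, because a number 6 percentage points higher from compound 1 to compound 3 (within the scatter) is the sole guide. The estimate for compound 4 is 12%, with a range from 0% to 26%.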

Compound 4, a percentage reported as inhibition, at one concentration (the size of the read-out at that concentration, not a potency): 53%
Estimate against measurement, compound 4: 41 percentage points below; the whole stated range lies below it.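

In this assay, propyl in place of benzoyloxy, on a saturated chain carbon, two bonds along the chain from an oxygen on a saturated carbon, brought a number 47 percentage points higher from compound 2 to compound 4 (beyond the scatter). Set beside the earlier instance, the same change did not carry over from one core to the other at the same size: the same change on two cores in this assay, a number 6 percentage points higher (within the scatter) from compound 1 to compound 3 and a number 47 percentage points higher (beyond the scatter) from compound 2 to compound 4, 41 percentage points apart, beyond the scatter of two such steps. This shows that, for these two pairs, the size of the step cannot be read from one core to the other, but it does not show which part of the cores lies behind the gap, and two pairs give no rule for any further core.

The compounds shown leave open whether the large step comes from the loss of benzoyloxy or from the arrival of propyl, as both happen in the one change. They also leave open how a longer chain such as hexyl in place of propyl, or a carboxylic acid in place of the ester on the core of compound 2, would read.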